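The source may report more compounds than this note shows. Statements on the series, on what has been measured and on what is new or still open speak of the compounds shown alone.

Three compounds share one core and were each tested in a functional assay on A549 cells (Homo sapiens) for antiproliferative activity, read by MTT assay, with a stated time of 48 h; on this read-out higher numbers stand for weaker inhibition and lower numbers for stronger inhibition. Compound 1 `O=C(/C=C/c1ccc(Cl)cc1)Nc1cc(-c2ccc(Br)cc2)[nH]n1` gives 1210 nM. Compound 3 `O=C(/C=C/c1ccc(Br)cc1)Nc1cc(-c2ccc(Br)cc2)[nH]n1` carries bromo in place of chloro on an aromatic carbon and gives 1360 nM; the change shows as a 1.1-fold higher number from compound 1 to compound 3 (0.05 log units; within the scatter). Compound 2 `O=C(/C=C\c1ccc(C(F)(F)F)cc1)Nc1cc(-c2ccccc2)[nH]n1` gives 880 nM, the lowest of the three numbers, yet its gaps to compound 1 and to compound 3 both lie within the scatter, so no real order among the three can be claimed.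

Compound 4 `COc1ccc(/C=C\C(=O)Nc2cc(-c3ccccc3)[nH]n2)cc1` differs from compound 2 in one place: methoxy in place of trifluoromethyl on an aromatic carbon. Going by the values given here, no measured pair shows this exchange. Among the compounds with values here, the only measured step, a 1.1-fold higher number from compound 1 to compound 3 (0.05 log units; within the scatter), concerns a different swap on that ring and stayed within the scatter, so it gives no direction for the present change. For compound 4 in this assay the direction is therefore open, and a shift beyond the scatter is not expected with any confidence. Compound 4 is estimated at 1000 nM, within a range of 400 nM to 2500 nM. This estimate corresponds to an expected step of a 1.1-fold higher number from compound 2 to compound 4 (0.06 log units; within the scatter).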

Compound 4, half-maximal inhibitory concentration: 1060 nM
Compound 4: the middle estimate sits 1.1-fold (0.03 log units) below what was measured; low and high end bracket the measured number.
By their numbers in this assay, from the lowest: compounds 2, 4, 1 and 3 (each within the scatter of the next).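

In this assay, methoxy in place of trifluoromethyl on the aromatic carbon para to a large group gives a 1.2-fold higher number from compound 2 to compound 4 (0.08 log units; within the scatter). This is the first exchange shown at this position on a ring without a bromo group on its other aromatic ring, and it swaps trifluoromethyl for a group with fewer heavy atoms and a hydrogen-bond acceptor, yet the number stays within the scatter. No measurement shown gives a reason for this result.

A single exchange cannot show whether the position accepts any group, so an amine, a carboxylic acid or a longer chain on this carbon could still move the number beyond the scatter. From the compounds shown here alone, it also remains open whether the same exchange would behave alike in the core of compound 1, which has a different double-bond geometry and a bromo group on its other aromatic ring.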